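Working notes: changing the aryl group on the shared core

The compounds below may be only part of what the source reports. "The series", "measured", "known", "first", "only" and "open" are said of these compounds alone.

In a functional assay on A549 cells (Homo sapiens) for inhibition, read by MTT assay, with a stated time of 48 h (on this read-out lower numbers stand for stronger inhibition and higher numbers for weaker inhibition), compound 1 (`COc1ccc(C(c2c[nH]c3ccc(Br)cc23)c2c[nH]c3ccc(Br)cc23)c(OC)c1`) gives 100000 nM, and compound 2 (`COc1ccc(C(c2c[nH]c3ccc(Br)cc23)c2c[nH]c3ccc(Br)cc23)cc1OC`) gives 12000 nM. Compound 2 therefore holds the lower of the two numbers. Compound 3 (`CN(C)c1ccc(C(c2c[nH]c3ccc(Br)cc23)c2c[nH]c3ccc(Br)cc23)cc1`) carries 4-(dimethylamino)phenyl in place of 3,4-dimethoxyphenyl on a saturated chain carbon bound to two aromatic carbons.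

Among the measured compounds shown here, only one measured step bears on this change, and only indirectly: an 8.3-fold lower number from compound 1 to compound 2 (0.92 log units; beyond the scatter). That modest step, beyond the scatter, shows that the number responds to a change in this aryl group. For the measured compounds named here, no measured compound carries the entering group, so the direction remains open and the range must stay wide. The expected step, a 1.3-fold higher number from compound 2 to compound 3 (0.10 log units; within the scatter), is small. For compound 3, the estimated value is 15000 nM, with an expected range of 4000 nM to 50000 nM.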

Compound 3, half-maximal inhibitory concentration: 25000 nM
The estimate for compound 3 lay 1.7-fold (0.22 log units) below the measured number, within the range that was stated.
By their numbers in this assay, from the lowest: compound 2; then compound 3; then compound 1.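

Moving to 4-(dimethylamino)phenyl on this saturated chain carbon gives a 2.1-fold higher number from compound 2 to compound 3 (0.32 log units; beyond the scatter) but also a 4.0-fold lower number from compound 1 to compound 3 (0.60 log units; beyond the scatter), so compound 3 falls between the two dimethoxyphenyl compounds, with both steps beyond the scatter. The number at this place therefore responds to more than the arrangement of two methoxy groups, and a nitrogen-bearing aryl group is not confined to the level of either dimethoxyphenyl compound, though it does not pass compound 2. No supporting data on hand account for this order.

As far as these compounds go, whether a single methoxy group or the dimethylamino group alone sets the level stays open, as compound 3 changes both the group and its substitution pattern. From the compounds shown here alone, how an unsubstituted phenyl, or a phenyl bearing a carboxylic acid, would rank on the shared core also remains open.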